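A few compounds are considered here, and "the series" means these few. Any claim that something is new, unique, unknown or untested is made for them only; others in the source may bear on it.

Among the measured compounds shown here, compound 1 `O=C(O)CCCCCCC(=O)Nc1ccc(C2=C(c3ccc(O)cc3)C3CC(S(=O)(=O)Oc4ccc(C(F)(F)F)cc4)C2O3)cc1` provides the only number in an assay on isolated protein for inhibition of protein deacetylase HDAC6 (Homo sapiens), read by fluorescence, with a stated time of 15 min (a lower number here means a stronger inhibitor, a higher number a weaker inhibitor), where compound 1 gives 648 nM. Compound 2 `O=S(=O)(Oc1ccccc1)[C@H]1C[C@H]2O[C@@H]1C(c1ccc(O)cc1)=C2c1ccc(O)cc1` is reported in this assay only as "not active" (no number reported), without a number. Compound 3 `O=C(O)CCCCCCC(=O)Nc1ccc(C2=C(c3ccc(O)cc3)C3CC(S(=O)(=O)Oc4ccc5ccccc5c4)C2O3)cc1` differs from compound 1 in one place: naphthalen-2-yl in place of 4-(trifluoromethyl)phenyl on an oxygen. For the measured compounds named here, no step between two measured compounds is known, so there is no measured change of this kind to lean on. The step from compound 1 to compound 3 is expected to be small, a 1.2-fold lower number from compound 1 to compound 3 (0.07 log units; within the scatter), within or close to the usual scatter. Compound 3 is therefore estimated at 550 nM, with a range from 200 nM to 1600 nM.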

Compound 3, half-maximal inhibitory concentration: 8110 nM
Compound 3: the middle estimate sits 15-fold (1.17 log units) below what was measured; measured number above the stated range.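

In this assay, the group on the oxygen bound to the sulfonyl sulfur is not interchangeable: naphthalen-2-yl in place of 4-(trifluoromethyl)phenyl gives a 13-fold higher number from compound 1 to compound 3 (1.10 log units; beyond the scatter). The two groups match in heavy-atom count, so that count alone does not set the read-out at this position. Nothing available explains the change. The compounds shown leave open whether the second aromatic ring or the absence of trifluoromethyl accounts for the step. A plain phenyl or a 4-chlorophenyl on the same oxygen, within the structure of compound 1, would help separate the two.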